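Shortening the amide substituent from benzyl to propyl

This account rests on a few compounds, and the source may have more. Where it says the series, first, only, none or still open, it means among the compounds named here.

Of the compounds shown here, three sharing the same aminothiazole-bearing core have been measured in an assay on membranes from Sf9 cells for displacement of a labelled ligand from histamine H2 receptor (Homo sapiens), read by scintillation counting, with a stated time of 60 min; a lower number here means a stronger inhibitor, a higher number a weaker inhibitor. Compound 1 `Cc1ccc(CC(C)CNC(=O)/N=C(\N)NCCCc2sc(N)nc2C)cc1` gives 72.4 nM. Compound 2 `CCCCCNC(=O)/N=C(\N)NCCCc1sc(N)nc1C` gives 4.47 nM. Within the data shown here, compound 3 `Cc1nc(N)sc1CCCN/C(N)=N/C(=O)NCc1ccccc1` gives 69.2 nM, placing it second highest of the three, near compound 1 and well above compound 2; the single comparable step, a 15-fold higher number from compound 2 to compound 3 (1.19 log units; beyond the scatter), was large. Compound 4 `CCCNC(=O)/N=C(\N)NCCCc1sc(N)nc1C` differs from compound 3 by ethyl in place of phenyl on a saturated chain carbon bound to an amide-type nitrogen. Since the replacement of a saturated chain by phenyl raised the number considerably, returning to a saturated chain in compound 4 is expected to lower it again, an 8.7-fold lower number from compound 3 to compound 4 (0.94 log units; beyond the scatter), though the chain is shorter than in compound 2. Compound 4 is therefore estimated at 8 nM, within 3 nM to 25 nM.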

Compound 4, inhibition constant: 105 nM
Beside the measured number, compound 4's estimate is 13-fold (1.12 log units) below it; measured number outside the range, above it.
By their numbers in this assay, from the lowest: compound 2; then compounds 3, 1 and 4 (each within the scatter of the next).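

In this assay, benzyl and propyl at this position cannot be told apart, with a 1.5-fold higher number from compound 3 to compound 4 (0.18 log units; within the scatter), so the presence of a phenyl ring does not separate compound 3 from compound 2. The ethyl on a saturated chain carbon, three bonds along the chain from an amide-type nitrogen, matters far more, since its removal gives a 23-fold higher number from compound 2 to compound 4 (1.37 log units; beyond the scatter). The 4-methylbenzyl on a saturated chain carbon bound to two saturated chain carbons makes no such difference, with a 1.5-fold higher number from compound 1 to compound 4 (0.16 log units; within the scatter). Nothing at hand explains these steps. The compounds shown leave open whether a longer chain than that of compound 2, or a chain ending in an amine, would keep its low number.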